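From Benzoyl to (3,5-Dimethoxyphenyl)carbonyl: One Expected Step

This account rests on a few compounds, and the source may have more. Where it says the series, first, only, none or still open, it means among the compounds named here.

Within the data shown here, in a functional assay on CHP-134 cells (Homo sapiens) for antiproliferative activity, with a stated time of 72 h (a lower number here means a stronger inhibitor, a higher number a weaker inhibitor), compound 2 `O=C(CCN(Cc1ccc(C(=O)NO)cc1)C(=O)c1ccccc1)NCc1ccccc1` gives 4680 nM, the higher of the two numbers so far, which makes it the weaker inhibitor of the pair. Among the measured compounds shown here, its only measured neighbour, compound 1 `Cc1cc(C)cc(C(=O)N(CCC(=O)NCc2ccccc2)Cc2ccc(C(=O)NO)cc2)c1`, gives 2030 nM. The next molecule, compound 3 `COc1cc(OC)cc(C(=O)N(CCC(=O)NCc2ccccc2)Cc2ccc(C(=O)NO)cc2)c1`, differs from compound 2 as follows: 3,5-dimethoxyphenyl in place of phenyl on a carbonyl carbon. In words, this places 3,5-dimethoxyphenyl in place of phenyl on a carbonyl carbon. For the measured compounds named here, the one measured step that bears on this is a 2.3-fold higher number from compound 1 to compound 2 (0.36 log units; beyond the scatter), a modest change with phenyl in place of 3,5-dimethylphenyl on a carbonyl carbon. Read in reverse, that step favours the substituted ring, but no measured compound yet carries 3,5-dimethoxyphenyl, so the guide is loose. The expected change is a 2.1-fold lower number from compound 2 to compound 3 (0.33 log units; beyond the scatter), again modest and towards a lower number. The estimate for compound 3 is 2200 nM, with an expected range of 900 nM to 5000 nM.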

Compound 3, half-maximal inhibitory concentration: 12300 nM
Compound 3: the middle estimate sits 5.6-fold (0.75 log units) below what was measured, outside the stated range (above it).
By their numbers in this assay, from the lowest: compound 1; then compound 2; then compound 3.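

In this assay, substitution on this ring does not act in one direction: placing 3,5-dimethoxyphenyl on the carbonyl carbon in place of phenyl gives a 2.6-fold higher number from compound 2 to compound 3 (0.42 log units; beyond the scatter) and so runs opposite to the gain seen with 3,5-dimethylphenyl. Exchanging 3,5-dimethylphenyl for 3,5-dimethoxyphenyl gives a 6.1-fold higher number from compound 1 to compound 3 (0.78 log units; beyond the scatter) and shows that the outcome here depends on which groups the ring carries, not merely on whether it carries any, with compound 3 the weakest of the three. Nothing available explains why these two substituted rings part ways.

Among these compounds, with only three rings compared, it remains open how a ring bearing one methoxy group, a chlorine atom or an amine would read. Whether the rise in compound 3 belongs to the methoxy groups themselves also stays unsettled until other oxygen-bearing groups, such as a hydroxyl or an ethoxy group, are seen at this position.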